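Compound 3: a new phenyl group at the assay limit

The compounds below may be only part of what the source reports. "The series", "measured", "known", "first", "only" and "open" are said of these compounds alone.

- compound 1 `Cc1c(C(=O)Nc2ccc(SC#N)cc2)nnn1-c1ccc(C(C)C)cc1`: > 100000 nM (a limit)
- compound 2 `Cc1ccc(-n2nnc(C(=O)Nc3ccc(SC#N)cc3)c2C)cc1C`: > 100000 nM (a limit)

Compound 2 gives no number in a functional assay on HEK293 cells (Homo sapiens) for antiproliferative activity, read by MTT assay, with a stated time of 72 h (a higher number here means a weaker inhibitor of growth, a lower number a stronger inhibitor of growth), only the limit > 100000 nM. Compound 1 shares that position, as the limit of > 100000 nM in this assay, at which 2 of the 2 values shown sit, shows. For the measured compounds named here, the one measured change of this group is a step that the two limits leave unreadable from compound 1 to compound 2, so it offers no size or direction to carry forward.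

Compound 3 `Cc1ccc(Cl)cc1-n1nnc(C(=O)Nc2ccc(SC#N)cc2)c1C` alters the same group: 5-chloro-2-methylphenyl in place of 3,4-dimethylphenyl on an aromatic nitrogen. Here 5-chloro-2-methylphenyl replaces 3,4-dimethylphenyl on an aromatic nitrogen of the ring.

With no readable step to draw on, no change beyond the scatter is expected in this assay. The expected step is a number no higher from compound 2 to compound 3 (the limit leaves the size open). Compound 3 is estimated at 100000 nM, with an expected range from 40000 nM to 200000 nM. A report of only a limit is the likeliest outcome.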

Compound 3, concentration for 50% growth inhibition: 91200 nM
Compound 3: the middle estimate sits 1.1-fold (0.04 log units) above what was measured; the range from low to high includes it.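

In this assay, for the compounds shown here, compound 3 gives 91200 nM, the first value at this position on the aromatic nitrogen that is a number and not a limit. Going by these compounds, the change to 5-chloro-2-methylphenyl gives an at least 1.0-fold lower number from compound 2 to compound 3 (0.04 log units; that floor lies within the scatter), and the change from 4-isopropylphenyl gives an at least 1.0-fold lower number from compound 1 to compound 3 (0.04 log units; that floor lies within the scatter); both steps are floors, so the true sizes stay unknown, and what can be read does not show a real gain in growth inhibition. Compound 1 and compound 2 still supply no number, so compound 3 has no measured partner for a full comparison: the limit of > 100000 nM in this assay, at which 2 of the 3 values shown sit.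

The compounds shown leave open whether the chloro group or the moved methyl group matters at all in 5-chloro-2-methylphenyl. They also leave open what an amine or a carboxylic acid on this phenyl ring would do.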